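A few compounds are considered here, and "the series" means these few. Any claim that something is new, unique, unknown or untested is made for them only; others in the source may bear on it.

Measured compounds and their numbers:
compound 1, `O=c1nc2oc(CCCCl)c(C#CCCCCl)c2cn1Cc1cn(-c2ccc(Cl)cc2)nn1`: 72500 nM
compound 2, `O=c1nc2oc(C3CC3)cc2cn1Cc1cn(-c2ccc(Cl)cc2)nn1`: > 100000 nM
compound 3, `O=c1nc2oc(CCCCl)cc2cn1Cc1cn(-c2ccc(Cl)cc2)nn1`: 89800 nM

In a functional assay on HepG2 cells (Homo sapiens) for antiproliferative activity, read by MTT assay, with a stated time of 72 h (a lower number here means a stronger inhibitor, a higher number a weaker inhibitor), compound 3 gives 89800 nM. Going by the values given here, the nearest neighbour, and the only other compound with a number, is compound 1, which gives 72500 nM. For compound 2 this assay reports only a limit, > 100000 nM, which is the limit of > 100000 nM in this assay, at which 1 of the 3 values shown sits.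

Two steps among these compounds are known. Going from compound 1 to compound 3 the number moves by a 1.2-fold higher number from compound 1 to compound 3 (0.09 log units; within the scatter), and going from compound 2 to compound 3 by an at least 1.1-fold lower number from compound 2 to compound 3 (0.04 log units; that floor lies within the scatter). Both steps concern substituents on the shared core, and neither reaches beyond the scatter.

Compound 4, `O=c1nc2oc(CCCCl)cc2cn1Cc1cn(-c2ccccc2F)nn1`, has not yet been measured. It differs from compound 3 by 2-fluorophenyl in place of 4-chlorophenyl on an aromatic nitrogen. Among the compounds with values here, no measured step touches the group on the aromatic nitrogen, so nothing here speaks directly to this change. The steps that are known are small, and the account has no ground to expect more than that here either: the step from compound 3 to compound 4 is expected to stay within the scatter, as a 1.0-fold higher number from compound 3 to compound 4 (0.00 log units; within the scatter). Compound 4 is therefore estimated at 90000 nM in this assay, between 40000 nM and 200000 nM.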

Compound 4, half-maximal inhibitory concentration: 79800 nM
The estimate for compound 4 lay 1.1-fold (0.05 log units) above the measured number; the measured number falls inside the stated range.
By their numbers in this assay, from the lowest: compounds 1, 4 and 3 (each within the scatter of the next). At a limit, above all of these: compound 2.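

Going by these compounds alone, the group on the aromatic nitrogen, which no earlier step touched, is now exchanged, and in this assay the swap of 4-chlorophenyl for 2-fluorophenyl gives a 1.1-fold lower number from compound 3 to compound 4 (0.05 log units; within the scatter), so this position, like the place on the core that carries the 5-chloropent-1-yn-1-yl group in compound 1, shows no step beyond the scatter for the pair at hand. Within the data shown here, the exchange keeps the count of heavy atoms and the six-membered aromatic ring of carbon, and it alters both the halogen and its place on that ring, so this single step says only that the two changes taken together leave the number within the scatter, not what each does alone. Compound 2 gives only a limit and not a number: the limit of > 100000 nM in this assay, at which 1 of the 4 values shown sits.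

On these data alone, what remains open is how far this position tolerates a change larger than one halogenated phenyl for another, such as a phenyl bearing an amine or a carboxylic acid, or a longer alkyl chain in place of the ring. Also open, as far as these compounds go, is whether any group at this position would bring the number well clear of the scatter, since both phenyl groups compared here share the same ring and differ only in their halogen.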